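Nitro in place of bromo: expectation for compound 4

The compounds below may be only part of what the source reports. "The series", "measured", "known", "first", "only" and "open" are said of these compounds alone.

Three compounds carry numbers in a functional assay on JAR cells (Homo sapiens) for inhibition, read by MTT assay, with a stated time of 72 h, tested at 10 uM; on this read-out higher numbers stand for more inhibition at the one concentration tested (going by the name of the read-out) and lower numbers for less inhibition. Compound 1 `CCOC(=O)C1=C(Nc2ccccc2)S/C(=C\c2cc(OC)c(O)c(OC)c2)C1=O` gives 57.5%. Compound 3 `CCOC(=O)C1=C(Nc2cccc(C(F)(F)F)c2)S/C(=C\c2ccc[nH]2)C1=O` gives 52.9%. Compound 2 `CCOC(=O)C1=C(Nc2ccc(Br)cc2)S/C(=C\c2ccc[nH]2)C1=O` gives 41.5%, the lowest of the three; its gap to compound 3 and its wider gap to compound 1 both lie beyond the scatter. Compound 4 `CCOC(=O)C1=C(Nc2ccc([N+](=O)[O-])cc2)S/C(=C\c2ccc[nH]2)C1=O` is not yet measured and differs from compound 2 by nitro in place of bromo on an aromatic carbon. For the measured compounds named here, no two measured compounds differ in a single place, so the size of such a change is unknown here. Since compound 3 gives 52.9% against compound 2 with 41.5%, a modest upward step in this assay is expected, near the edge of the scatter. Compound 4 is expected to give 48%, between 35% and 62%. This amounts to an expected step of a number 6.5 percentage points higher from compound 2 to compound 4 (within the scatter) in this assay.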

Compound 4, a percentage reported as inhibition, at one concentration (the size of the read-out at that concentration, not a potency): 54.9%
Estimate against measurement, compound 4: 6.9 percentage points below; measured number inside the range.
By their numbers in this assay, from the lowest: compound 2; then compounds 3, 4 and 1 (each within the scatter of the next).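

In this assay, nitro in place of bromo on an aromatic carbon, para to a large group, gives a number 13.4 percentage points higher from compound 2 to compound 4 (beyond the scatter). For the compounds shown here, this is the first step that isolates a single place, and it shows that the read-out at this position depends on the group it carries. Nothing measured here bears on the reason for the step.

Going by these compounds, whether an amine or a carboxylic acid at this position would give a similar number remains open. Also open, on these data alone, is whether the same change would give a similar step on the core of compound 1.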